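Benzyloxy gives way on an amide-type nitrogen

A few compounds are considered here, and "the series" means these few. Any claim that something is new, unique, unknown or untested is made for them only; others in the source may bear on it.

Compound 1 (`COc1cc(NC(C)CCCNC(=O)NCCO)c2ncccc2c1`): > 100000 nM, a limit
Compound 2 (`COc1cc(NC(C)CCCNC(=O)NOCc2ccccc2)c2ncccc2c1`): 20000 nM

For the measured compounds named here, in a functional assay on SW-620 cells (Homo sapiens) (on this read-out lower numbers stand for stronger inhibition and higher numbers for weaker inhibition), compound 2 gives 20000 nM, the only actual number so far. Compound 1 stands at the limit of > 100000 nM in this assay, at which 1 of the 2 values shown sits.

The next compound, compound 3 (`COc1cc(NC(C)CCCNC(=O)NC(CO)(CO)CO)c2ncccc2c1`), carries 2-hydroxy-1,1-bis(hydroxymethyl)ethyl in place of benzyloxy on an amide-type nitrogen. The change removes the one six-membered aromatic ring of carbon only and leaves no ring in the new group.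

Going by the values given here, only one measured step bears on this: an at least 5.0-fold lower number from compound 1 to compound 2 (0.69 log units; beyond the scatter). There, benzyloxy took the place of 2-hydroxyethyl at the same kind of nitrogen. Going by these compounds, it rests on a limit, so its full size is unknown. Compound 3 loses benzyloxy as well, so the earlier step is expected to run largely in reverse, towards weaker inhibition. The expected change is a 5.0-fold higher number from compound 2 to compound 3 (0.70 log units; beyond the scatter), beyond the scatter. A report as a limit alone is more likely than not. For compound 3 the estimated value is 100000 nM, with an expected range of 40000 nM to 250000 nM.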

Compound 3, half-maximal inhibitory concentration: > 100000 nM
Compound 3: no number, only a limit; the forecaster's own chance of this, stated with the estimate: 70%; the middle value sits exactly at the limit.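

With 2-hydroxy-1,1-bis(hydroxymethyl)ethyl in place of benzyloxy on the amide-type nitrogen, this assay shows an at least 5.0-fold higher number from compound 2 to compound 3 (0.69 log units; beyond the scatter). Among the three compounds, the only measured number therefore still belongs to the one carrying benzyloxy, the only group here at this nitrogen with a six-membered aromatic ring of carbon only, and two different ring-free groups, 2-hydroxyethyl and 2-hydroxy-1,1-bis(hydroxymethyl)ethyl, now both end at a limit: the limit of > 100000 nM in this assay, at which 2 of the 3 values shown sit. The step between those two ring-free compounds cannot be read, as both values are limits, so no order between them follows.

The compounds shown leave open whether the aromatic ring or the oxygen of benzyloxy accounts for the difference, a question that a plain benzyl group or a phenyl group on the same nitrogen would help to separate. They also leave open how much further the number can fall from the value of compound 2 at 20000 nM, for instance with a longer chain such as 2-phenylethoxy or with a chlorine atom on the aromatic ring of benzyloxy.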